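Amide-to-ester swap at the glycine carbonyl of the spiro series

A few compounds are considered here, and "the series" means these few. Any claim that something is new, unique, unknown or untested is made for them only; others in the source may bear on it.

Compound 3 `CC1CCCN(C(=O)CN2CN(c3ccccc3)C3(CCN(C(=O)c4ccc(C5CCCCC5)cc4)CC3)C2=O)C1` stands highest in an assay on HEK293 cells for displacement of a labelled ligand from NPC1-like intracellular cholesterol transporter 1 (Homo sapiens) (a lower number here means a stronger inhibitor, a higher number a weaker inhibitor), at 3600 nM, above compound 2 `CC(C)(C)OC(=O)NCNC(=O)CN1CN(c2ccccc2)C2(CCN(C(=O)c3ccc(C4CCCCC4)cc3)CC2)C1=O` at 1700 nM and compound 1 `CCOC(=O)C1CCN(C(=O)CN2CN(c3ccccc3)C3(CCN(C(=O)c4ccc(C5CCCCC5)cc4)CC3)C2=O)CC1` at 900 nM. Compound 4 `CC1(C)CC(OC(=O)CN2CN(c3ccccc3)C3(CCN(C(=O)c4ccc(C5CCCCC5)cc4)CC3)C2=O)CC(C)(C)N1` differs from compound 3 by (2,2,6,6-tetramethylpiperidin-4-yl)oxy in place of 3-methylpiperidin-1-yl on a carbonyl carbon. The same carbonyl carbon was varied in every measured step: a 1.9-fold higher number from compound 1 to compound 2 (0.28 log units; within the scatter), a 4.0-fold higher number from compound 1 to compound 3 (0.60 log units; beyond the scatter) and a 2.1-fold higher number from compound 2 to compound 3 (0.33 log units; beyond the scatter), so changes here have moved this assay by modest amounts only. Compound 4 brings in a group unlike any measured one, so the direction is uncertain. Since compound 3 sits at the top of the span, a step toward a lower number, up to the size of the largest measured step, is taken as the working expectation. For compound 4 the expected step is a 1.8-fold lower number from compound 3 to compound 4 (0.26 log units; within the scatter). Compound 4 is therefore estimated at 2000 nM, between 600 nM and 7000 nM.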

Compound 4, half-maximal inhibitory concentration: 600 nM
Compound 4: the middle estimate sits 3.3-fold (0.52 log units) above what was measured; the measured number falls inside the stated range.
By their numbers in this assay, from the lowest: compounds 4, 1 and 2 (each within the scatter of the next, the first and the last beyond it); then compound 3.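

In this assay, an ester at this carbonyl carbon is not merely tolerated: a 6.0-fold lower number from compound 3 to compound 4 (0.78 log units; beyond the scatter) is wider than any step among the amides, and a 2.8-fold lower number from compound 2 to compound 4 (0.45 log units; beyond the scatter) also lies beyond the scatter. Against the best amide the picture is level, with a 1.5-fold lower number from compound 1 to compound 4 (0.18 log units; within the scatter), so (2,2,6,6-tetramethylpiperidin-4-yl)oxy matches 4-(ethoxycarbonyl)piperidin-1-yl without surpassing it.

Open, from the compounds shown here alone, is whether the ester oxygen or the tetramethylpiperidine ring drives the step; the same ring joined through an amine, or a plain cyclohexyl ester, would separate the two. No measurement at hand accounts for the step.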